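This account rests on a few compounds, and the source may have more. Where it says the series, first, only, none or still open, it means among the compounds named here.

Compound 2 `CC(=O)OC1=CC(=O)c2ccccc2C1=O` gives the higher of the two numbers recorded in a functional assay on HeLa cells (Homo sapiens) for cytotoxicity; on this read-out higher numbers stand for weaker inhibition and lower numbers for stronger inhibition: compound 2 gives 62100 nM, while compound 1 `CCOC1=CC(=O)c2ccccc2C1=O` gives 23800 nM. Within the data shown here, the only step connecting the two is a 2.6-fold higher number from compound 1 to compound 2 (0.42 log units; beyond the scatter), acetyl in place of ethyl on an oxygen on an unsaturated carbon. Compound 3 `O=C1C=C(Oc2ccco2)C(=O)c2ccccc21` is not yet measured in this assay; its change from compound 2 is furan-2-yl in place of acetyl on an oxygen on an unsaturated carbon. Among the measured compounds shown here, that step bears on the same oxygen as the step from compound 1 to compound 2, but it swaps acetyl for an aromatic ring rather than for ethyl, so the one measured step is only a loose guide. Compound 3 is expected to fall between its two neighbours, and the step of a 1.9-fold lower number from compound 2 to compound 3 (0.29 log units; within the scatter) is estimated to run downward by a modest amount. Compound 3 is therefore estimated at 32000 nM, within a range from 10000 nM to 100000 nM.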

Compound 3, half-maximal inhibitory concentration: 37000 nM
Beside the measured number, compound 3's estimate is 1.2-fold (0.06 log units) below it; the measured number falls inside the stated range.
By their numbers in this assay, from the lowest: compounds 1, 3 and 2 (each within the scatter of the next, the first and the last beyond it).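

Among these compounds, with furan-2-yl on the oxygen, an aromatic ring stands at this position for the first time, and in this assay this change gives a 1.7-fold lower number from compound 2 to compound 3 (0.22 log units; within the scatter) and a 1.6-fold higher number from compound 1 to compound 3 (0.19 log units; within the scatter). Compound 3 therefore cannot be told apart from either neighbour, even though the ethyl and acetyl compounds differ beyond the scatter, so this one ring at this position does not separate itself from the two open-chain groups. Nothing measured here accounts for these numbers. On these data alone, whether an amine, a carboxylic acid or a longer chain on the same oxygen would move the number beyond the scatter remains open. So does whether a phenyl ring would read like furan-2-yl, which would show if this result extends to aromatic rings generally.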